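The source may report more compounds than this note shows. Statements on the series, on what has been measured and on what is new or still open speak of the compounds shown alone.

Measured so far:
Compound 1 `CCC(C)n1cnc2c(NCc3ccc(C(=O)Nc4ccccc4N)cc3)nc(Cl)nc21` gives 45% in a functional assay on HepG2 cells (Homo sapiens) for antiproliferative activity, read by CCK-8 assay, with a stated time of 72 h, tested at 2 uM; on this read-out lower numbers stand for a weaker effect and higher numbers for a stronger effect at the one concentration tested.
Compound 2 `Cc1ccc(Nc2nc(Cl)nc3c2ncn3Cc2ccc(C(=O)Nc3ccccc3N)cc2)cc1` gives 76.2% in this assay.

Of these two numbers, compound 1 stands lowest; compound 2 lies beyond the usual scatter above it, but the two structures differ in more than one place, so that gap cannot be tied to a single change. Compound 3 `Nc1ccccc1NC(=O)c1ccc(CNc2nc(Cl)nc3c2ncn3Cc2ccccc2)cc1` differs from compound 1 in one place only: benzyl in place of sec-butyl on an aromatic nitrogen. Within the data shown here, no measured pair shows this exact exchange, so the size of the step in this assay is not known from the data at hand. A modest shift is expected, more likely upward than downward, though it could well stay within the scatter; the expected step is a number 7 percentage points higher from compound 1 to compound 3 (within the scatter). Compound 3 is therefore expected to give about 52%, with a likely range from 32% to 72%.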

Compound 3, a percentage reported as inhibition, at one concentration (the size of the read-out at that concentration, not a potency): 5.01%
The estimate for compound 3 lay 47 percentage points above the measured number; measured number below the stated range.
By their numbers in this assay, from the lowest: compound 3; then compound 1; then compound 2.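

Among these compounds, exchanging sec-butyl for benzyl on the aromatic nitrogen of the five-membered ring gives, in this assay, a number 40 percentage points lower from compound 1 to compound 3 (beyond the scatter), and this is the first change that can be read on its own. The group on this nitrogen therefore matters a great deal: with everything else in the molecule held the same, this one exchange takes away most of the effect seen with sec-butyl. Nothing at hand explains why the step is so large.

The compounds shown leave open whether the loss follows from the aromatic ring itself or simply from a larger group, a question that a cyclohexyl or cyclohexylmethyl group on the same nitrogen could address. They also leave open how a smaller methyl group, a longer chain or a chain ending in an amine would behave at this position.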